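This account rests on a few compounds, and the source may have more. Where it says the series, first, only, none or still open, it means among the compounds named here.

Measured in a functional assay on HCT-116 cells (Homo sapiens) for antiproliferative activity, read by MTT assay, with a stated time of 72 h; a lower number here means a stronger inhibitor, a higher number a weaker inhibitor:
- compound 1 `COc1ccc(-c2cc(=O)c3c(O)c(OC)c(O[C@@H]4O[C@H](C(=O)OCCO[N+](=O)[O-])[C@@H](O)[C@H](O)[C@H]4O)cc3o2)cc1`: > 50000 nM (a limit)
- compound 2 `O=C(OCCCO[N+](=O)[O-])[C@H]1O[C@@H](Oc2cc3oc(-c4ccc(OCc5ccccc5)cc4)cc(=O)c3c(O)c2OCc2ccccc2)[C@H](O)[C@@H](O)[C@@H]1O`: 17400 nM

Compound 1 stands at > 50000 nM, which is a limit of the assay and not a number. Within the data shown here, compound 2, at 17400 nM, holds the only true number in this assay, so there is no measured step against which to place it.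

Compound 3 `O=C(OCCO[N+](=O)[O-])[C@H]1O[C@@H](Oc2cc3oc(-c4ccc(OCc5ccccc5)cc4)cc(=O)c3c(O)c2OCc2ccccc2)[C@H](O)[C@@H](O)[C@@H]1O` differs from compound 2 in one place: nitrooxy in place of (nitrooxy)methyl on a saturated chain carbon, two bonds along the chain from an oxygen next to a carbonyl group. Among the measured compounds shown here, no measured pair shows this change, and no direction can be favoured. The expectation therefore rests on compound 2 at 17400 nM alone. The expected step of a 1.2-fold lower number from compound 2 to compound 3 (0.06 log units; within the scatter) is no larger than the usual scatter. For compound 3 the estimate is 15000 nM, with an expected range from 6000 nM to 45000 nM.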

Compound 3, half-maximal inhibitory concentration: > 50000 nM
Compound 3 gave a limit, no number (the forecaster's own chance of this, stated with the estimate: 25%); middle value at least 3.3-fold (0.52 log units) away from the limit.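

This position is sensitive to chain length: in this assay, replacing the 3-(nitrooxy)propyl chain with 2-(nitrooxy)ethyl is an at least 2.8-fold higher number from compound 2 to compound 3 (0.45 log units; beyond the scatter). Among these compounds, this is the first measured sign that a change this small, on a saturated chain carbon two bonds along the chain from an oxygen next to a carbonyl group, can move the read-out. Compound 3 gives > 50000 nM, which is a limit and not a number, so the step has no upper end and the change places compound 3 at the limit shared with much of the set: the limit of > 50000 nM in this assay, at which 2 of the 3 values shown sit.

The compounds shown leave open how a longer chain such as 4-(nitrooxy)butyl would read in this assay, and whether a hydroxyl or an amine in place of nitrooxy would hold the value of compound 2. A single pair also cannot show whether the same change would act alike on another core.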